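The source may report more compounds than this note shows. Statements on the series, on what has been measured and on what is new or still open speak of the compounds shown alone.

Measured so far:
compound 1 `CC1CC=C(C(=O)N(c2cc(C#CC(C)(C)C)sc2C(=O)O)C(C)C)CC1` — 0.08
compound 2 `C[C@@H](CCOc1cccnc1)N(c1cc(C#CC(C)(C)C)sc1C(=O)O)C(=O)[C@H]1CC[C@H](C)CC1` — 0.02

For the measured compounds named here, in an ADME assay for protein binding, using equilibrium dialysis, at pH 7.4, tested at 2 uM (on this read-out higher numbers stand for a larger free fraction and lower numbers for a smaller free fraction), compound 1 gives 0.08, the higher of the two numbers known here; compound 2 gives 0.02, and the gap between the two is beyond the scatter. Compound 3 `CC(C)N(c1cc(C#CC(C)(C)C)sc1C(=O)O)C(=O)[C@H]1CC[C@H](Cl)CC1` is not yet measured. It differs from compound 1 by a single change: 4-chlorocyclohexyl in place of 4-methylcyclohex-1-en-1-yl on a carbonyl carbon. Going by the values given here, no measured pair shows this change on its own. Compound 3 is therefore expected to sit close to compound 1, with a step of a 1.3-fold lower number from compound 1 to compound 3 (0.12 log units; within the scatter) that stays within the scatter, and a value estimated at 0.06, somewhere between 0.03 and 0.12.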

Compound 3, unbound fraction: 0.14
Beside the measured number, compound 3's estimate is 2.3-fold (0.37 log units) below it; measured number above the stated range.
By their numbers in this assay, from the lowest: compound 2; then compounds 1 and 3 (each within the scatter of the next).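

In this assay, 4-chlorocyclohexyl in place of 4-methylcyclohex-1-en-1-yl on a carbonyl carbon gives a 1.8-fold higher number from compound 1 to compound 3 (0.24 log units; within the scatter), the first single-place comparison available at this position. This exchange of a methyl-bearing ring with a double bond for a chlorine-bearing ring without one therefore leaves no shift that stands clear of the scatter. Nothing at hand bears on the reason for this result. From the compounds shown here alone, what a hydroxyl or an amine in place of the chlorine would do stays open, as does whether a longer chain could replace the ring on this carbonyl carbon.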